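The source may report more compounds than this note shows. Statements on the series, on what has been measured and on what is new or still open speak of the compounds shown alone.

Three compounds have so far been examined in an ADME assay on cells for inhibition of anoctamin-2 (Homo sapiens), read by fluorescence, with a stated time of 20 min; on this read-out lower numbers stand for stronger inhibition and higher numbers for weaker inhibition. Compound 1 `COc1ccccc1-c1nnc(-c2cc3cc(Cl)ccc3o2)o1` reaches only a limit of the assay, > 100000 nM. Compound 2 `Cc1cc(Cl)ccc1OCc1nnc(-c2ccccc2OC(F)(F)F)o1` is reported as "not active" (no number reported), without a number. Compound 3 `Cc1cc(Cl)ccc1OC(C)C(=O)N/N=C/c1ccccc1OC(F)(F)F` is likewise reported as "not active" (no number reported), with no number attached, so compound 3 stands among results that show no measurable inhibition. Compound 4 `Cc1cc(Cl)ccc1OCC(=O)N/N=C/c1ccccc1OC(F)(F)F` differs from compound 3 by hydrogen in place of methyl on a saturated chain carbon bound to a carbonyl carbon and an oxygen on an aromatic ring. Among the measured compounds shown here, no step between measured compounds is available to read a size from, and the expectation is of no change beyond the usual scatter. Compound 4 is therefore expected to give about 150000 nM in this assay, somewhere between 50000 nM and 500000 nM.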

Compound 4, half-maximal inhibitory concentration: "not active" (no number reported)
Compound 4: no number reported; there is nothing to compare the estimate with.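

Compound 3 and compound 4 are both reported as not active, without a number, so no step can be read from replacing methyl with hydrogen. The compounds shown leave open what inhibition, if any, these structures reach in this assay, as the only figure given is a limit: the limit of > 100000 nM in this assay, at which 1 of the 4 values shown sits.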